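Removing a Trifluoromethyl from a Benzamide at the Assay Limit

This account rests on a few compounds, and the source may have more. Where it says the series, first, only, none or still open, it means among the compounds named here.

Compound 1 `COc1cc(-c2nn(-c3cccc(NC(=O)c4cccc(C(F)(F)F)c4)c3)cc2-c2ccncc2)ccc1Cl` in a functional assay on OVCAR-3 cells (Homo sapiens) for inhibition, read by sulforhodamine B assay, with a stated time of 48 h (a higher number here means that more compound is tolerated, a lower number that less compound is tolerated), gives > 50000 nM, which is a limit of the assay.
Compound 2 `COc1cc(-c2nn(-c3cccc(NC(=O)Nc4ccc(Cl)c(Cl)c4)c3)cc2-c2ccncc2)ccc1Cl` in this assay gives > 50000 nM, also a limit.
Compound 3 `O=C(Nc1cccc(-n2cc(-c3ccncc3)c(-c3ccc(Cl)c(O)c3)n2)c1)Nc1cc(C(F)(F)F)cc(C(F)(F)F)c1` in this assay gives 3310 nM.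

Compound 1 therefore has no number of its own; it sits at the limit of > 50000 nM in this assay, at which 2 of the 3 values shown sit, together with compound 2. Compound 4 `COc1cc(-c2nn(-c3cccc(NC(=O)c4ccccc4)c3)cc2-c2ccncc2)ccc1Cl` differs from compound 1 by hydrogen in place of trifluoromethyl on an aromatic carbon. Within the data shown here, the only measured step touching that part of the molecule is a step that the two limits leave unreadable from compound 1 to compound 2, which runs between two limits and cannot be read. Among the measured compounds shown here, no measured step bears on dropping the trifluoromethyl, so in this assay no move beyond the scatter is expected, and a limit is again the most likely outcome. Compound 4 is estimated at 60000 nM, between 20000 nM and 200000 nM. The expected step is a step that the limit leaves unreadable from compound 1 to compound 4.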

Compound 4, concentration lethal to 50% of the cells: 95800 nM
Compound 4: the middle estimate sits 1.6-fold (0.20 log units) below what was measured; measured number inside the range.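

No step to compound 4 can be read from compound 1 or compound 2, because both stand at a limit: the limit of > 50000 nM in this assay, at which 2 of the 4 values shown sit.

The compounds shown leave open how far replacing the trifluoromethyl of compound 1 with hydrogen moves the result in this assay.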